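The compounds below may be only part of what the source reports. "The series", "measured", "known", "first", "only" and "open" are said of these compounds alone.

Of the compounds shown here, three from this series have been tested so far in an in vitro functional assay on SH-SY5Y cells for agonist activity at Neuronal acetylcholine receptor; alpha3/beta4 (Homo sapiens), read by FLIPR and calcium flux; on this read-out lower numbers stand for an effect already at smaller amounts and higher numbers for an effect only at larger amounts of compound. Compound 1 `Fc1ccc(C2=CC3CNCC(C2)C3)cn1` gives 99 nM. Compound 2 `C1=C(c2cncnc2)CC2CNCC1C2`, which carries a different six-membered aromatic ring and no fluoro, gives 198 nM. As far as these compounds go, compound 3 `CN1CC2C=C(c3ccc(F)nc3)CC(C2)C1` is where the picture changes: in this assay compound 3 reports only a limit, > 10000 nM, so its true value is unknown beyond that limit (the limit of > 10000 nM in this assay, at which 1 of the 3 values shown sits). Going by the values given here, the one measured step that reaches compound 3 is an at least 100-fold higher number from compound 1 to compound 3 (2.00 log units; beyond the scatter), which puts compound 3 far beyond the two compounds that gave numbers.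

The next compound, compound 4 `COc1ccc(C2=CC3CC(C2)CN(C)C3)cn1`, keeps the methyl on the ring amine of compound 3 and changes only the aromatic substituent: methoxy in place of fluoro on an aromatic carbon. Among the compounds with values here, no measured pair among compounds 1, 2 and 3 involves a fluoro-to-methoxy exchange, so no step in hand speaks directly to this change. Within the data shown here, the only step that bears on compound 4 is the large one from compound 1 to compound 3, and it concerns the methyl on the amine, which compound 4 retains. Compound 4 is therefore expected to stay at or near the limit, with a step that the limit leaves unreadable from compound 3 to compound 4, giving an estimate of 20000 nM within a range from 3000 nM to 100000 nM.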

Compound 4, half-maximal effective concentration: 1890 nM
For compound 4 the middle estimate is 11-fold (1.02 log units) above the measured one; measured number below the stated range.
By their numbers in this assay, from the lowest: compounds 1 and 2 (each within the scatter of the next); then compound 4. At a limit, above all of these: compound 3.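

In this assay, the place on the aromatic ring next to the ring nitrogen and para to a large group turns out to matter: methoxy in place of fluoro there gives an at least 5.2-fold lower number from compound 3 to compound 4 (0.72 log units; beyond the scatter). The methyl on the ring amine therefore does not by itself rule out a measured value, as compound 4 carries that methyl and still gives a real number, 1890 nM. The full size of this step cannot be read, because compound 3 stands at a limit and the step is only a lower bound: the limit of > 10000 nM in this assay, at which 1 of the 4 values shown sits.

The only fluoro-to-methoxy pair shown carries the methyl on the ring amine, so it remains open whether the same exchange would also lower the number with hydrogen on that nitrogen, as in compound 1. Also open, as far as these compounds go, is what other groups at this place would give, such as an amine, a chloro group or the longer ethoxy, and whether the oxygen of methoxy or simply its extra heavy atom accounts for the change.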